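Piperidine Amide in Place of Morpholine Amide

The compounds below may be only part of what the source reports. "The series", "measured", "known", "first", "only" and "open" are said of these compounds alone.

Compound 3 `CCN(CC)S(=O)(=O)c1ccc(S(=O)(=O)N2CCC[C@@H](C(=O)N3CCOCC3)C2)cc1` was tested in a functional assay on MIA PaCa-2 cells (Homo sapiens) for inhibition, read by MTT assay, with a stated time of 3 days; a higher number here means a weaker inhibitor, a lower number a stronger inhibitor. In this assay compound 3 gives only a limit, > 10000 nM, not a number. Its close relative compound 2 `CCN(CC)S(=O)(=O)c1ccc(S(=O)(=O)N2CCC[C@@H](C(=O)N3CCS(=O)(=O)CC3)C2)cc1` likewise returns only a limit, > 10000 nM. The step that the two limits leave unreadable from compound 2 to compound 3 therefore cannot be read. Compound 1 `O=C([C@@H]1CCCN(S(=O)(=O)c2ccc(S(=O)(=O)C3CCC3)cc2)C1)N1CCC(F)(F)CC1` also reaches only a limit in this assay, > 3000 nM. Two of the three values sit at the limit of > 10000 nM in this assay, at which 2 of the 3 values shown sit, and one at the limit of > 3000 nM in this assay, at which 1 of the 3 values shown sits. Compound 4 `CCN(CC)S(=O)(=O)c1ccc(S(=O)(=O)N2CCC[C@@H](C(=O)N3CCC(C(F)F)CC3)C2)cc1` differs from compound 3 by 4-(difluoromethyl)piperidin-1-yl in place of morpholin-4-yl on a carbonyl carbon. Going by the values given here, no measured step bears on this change, and none of the measured values shows any inhibition. Compound 4 is expected to stay weak, with the estimated step that the limit leaves unreadable from compound 3 to compound 4 meaning no change beyond the scatter. The estimate for compound 4 is 12000 nM, between 3000 nM and 40000 nM.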

Compound 4, half-maximal inhibitory concentration: > 10000 nM
Compound 4 gave a limit, no number (the forecaster's own chance of this, stated with the estimate: 80%); the middle value lies beyond the limit too.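

Compound 4, like compound 2 and compound 3, gives only a limit, so the steps among these three compounds cannot be read: the limit of > 10000 nM in this assay, at which 3 of the 4 values shown sit.

On these data alone, whether any group on the carbonyl carbon of this shared core can give a true number rather than a limit stays open.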